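A few compounds are considered here, and "the series" means these few. Any claim that something is new, unique, unknown or untested is made for them only; others in the source may bear on it.

In a functional assay on DU-145 cells (Homo sapiens) for cytotoxicity, read by trypan blue exclusion, with a stated time of 96 h (a lower number here means a stronger inhibitor, a higher number a weaker inhibitor), compound 1 `COc1cc(OC)c(/C=C/S(=O)(=O)Cc2ccc(OC)c(N)c2)c(OC)c1` gives 4 nM and compound 2 `COC(=O)CNc1cc(CS(=O)(=O)/C=C/c2c(OC)cc(OC)cc2OC)ccc1OC` gives 100 nM while compound 3 `COC(=O)[C@H](C)Nc1cc(CS(=O)(=O)/C=C/c2c(OC)cc(OC)cc2OC)ccc1OC` gives 750 nM as the highest number of the three. Compound 4 `COC(=O)C(F)(F)Nc1cc(CS(=O)(=O)/C=C/c2c(OC)cc(OC)cc2OC)ccc1OC` differs from compound 3 by one change, difluoro(methoxycarbonyl)methyl in place of 1-(methoxycarbonyl)ethyl on a nitrogen on an aromatic ring with difluoro(methoxycarbonyl)methyl in place of 1-(methoxycarbonyl)ethyl on a nitrogen on an aromatic ring. Bearing on this are a 25-fold higher number from compound 1 to compound 2 (1.40 log units; beyond the scatter) and a 190-fold higher number from compound 1 to compound 3 (2.27 log units; beyond the scatter) for substitution on that nitrogen, and a 7.5-fold higher number from compound 2 to compound 3 (0.88 log units; beyond the scatter) for adding a methyl to the chain. Among the compounds with values here, no measured step covers the fluorine atoms, so no step beyond the scatter is firmly expected in this assay and the direction stays open. For compound 4 the expected step is a 1.3-fold lower number from compound 3 to compound 4 (0.10 log units; within the scatter) by this estimate. The estimate for compound 4 is 600 nM with an expected range from 120 nM to 3000 nM around it.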

Compound 4, half-maximal inhibitory concentration: 250 nM
Compound 4: the middle estimate sits 2.4-fold (0.38 log units) above what was measured; the measured number falls inside the stated range.
By their numbers in this assay, from the lowest: compound 1; then compound 2; then compound 4; then compound 3.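

In this assay there is a 3.0-fold lower number from compound 3 to compound 4 (0.48 log units; beyond the scatter) when difluoro(methoxycarbonyl)methyl replaces 1-(methoxycarbonyl)ethyl on the nitrogen, so two fluorines on that chain carbon cost less than one methyl. Even so, there is a 2.5-fold higher number from compound 2 to compound 4 (0.40 log units; beyond the scatter) and also a 63-fold higher number from compound 1 to compound 4 (1.80 log units; beyond the scatter) on the same nitrogen, so the fluorinated chain does not return to the number of either simpler compound, and the free amine of compound 1 stays lowest of the four. Nothing shown here explains this order. Going by these compounds, whether a carboxylic acid in place of the methyl ester, or a longer chain on the nitrogen, would narrow the gap to compound 1 remains open.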